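The source may report more compounds than this note shows. Statements on the series, on what has been measured and on what is new or still open speak of the compounds shown alone.

Measured in an ADME assay on L929 cells (Mus musculus) for cytotoxicity, read by MTT assay, with a stated time of 72 h; on this read-out lower numbers stand for higher toxicity in this test and higher numbers for lower toxicity in this test:

compound 1 `CCOC(=O)c1[nH]c(=O)c(C#N)cc1C(=O)c1ccc(C)cc1` — 512000 nM
compound 2 `O=C(c1ccc([N+](=O)[O-])cc1)c1cc(C(=O)O)c(=O)[nH]c1C(=O)O` — 439000 nM

For the measured compounds named here, only two compounds carry a number in this assay. Compound 1 and compound 2 lie within the usual scatter of one another, so neither can be set apart; compound 1 simply stands level with compound 2 at the low-toxicity end of what has been seen.

Compound 3 `CCOC(=O)c1[nH]c(=O)c(C#N)cc1C(=O)c1ccc(OC)cc1` is not yet measured. It differs from compound 1 in one place: methoxy in place of methyl on an aromatic carbon. Going by the values given here, no pair of measured compounds shows the effect of this change, so there is no step to lean on. Both measured compounds sit close together despite differing widely in their other substituents, which suggests the series is fairly flat in this assay. The expected step from compound 1 to compound 3 is therefore small, a 1.1-fold lower number from compound 1 to compound 3 (0.06 log units; within the scatter), with no clear direction beyond the scatter. Compound 3 is estimated at 450000 nM, expected within 200000 nM to 1000000 nM.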

Compound 3, half-maximal cytotoxic concentration: 259000 nM
Beside the measured number, compound 3's estimate is 1.7-fold (0.24 log units) above it, within the range that was stated.
By their numbers in this assay, from the lowest: compounds 3, 2 and 1 (each within the scatter of the next).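

In this assay, methoxy in place of methyl on an aromatic carbon, para to a large group, gives a 2.0-fold lower number from compound 1 to compound 3 (0.30 log units; within the scatter) and so does not set the two compounds apart. For the compounds shown here, this is the first one-place reading at this position, and it places the 4-methoxyphenyl compound level with the 4-methylphenyl compound, even with the added hydrogen-bond acceptor counted for methoxy. No measurement at hand speaks to what lies behind this reading.

As far as these compounds go, whether an amine, a chlorine atom or a longer alkoxy chain at this same position would give a step beyond the scatter remains open. From the compounds shown here alone, it is also open whether the change from methyl to methoxy reads the same once the nitrile of the shared core is replaced by a primary amide.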